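The compounds below may be only part of what the source reports. "The series", "measured", "known", "first", "only" and "open" are said of these compounds alone.

Series notes. Compound 1 `CC(C(=O)NCc1ccc(C(F)(F)F)cc1OCc1ccc(F)cc1)c1ccc(NS(C)(=O)=O)c(F)c1` gives 0.5 nM in an assay on CHO cells for antagonist activity at transient receptor potential cation channel subfamily V member 1 (Homo sapiens), read by FLIPR; a higher number here means a weaker inhibitor, a lower number a stronger inhibitor. Within the data shown here, compound 2 `CC(C)CCSc1cc(C(F)(F)F)ccc1CNC(=O)C(C)c1ccc(NS(C)(=O)=O)c(F)c1` gives 1.4 nM in this assay; this is the highest of the two numbers so far, its nearest neighbour being compound 1, with the step of a 2.8-fold higher number from compound 1 to compound 2 (0.45 log units; beyond the scatter) beyond the scatter. Compound 3 `CC(C(=O)NCc1ccc(C(F)(F)F)cc1Cl)c1ccc(NS(C)(=O)=O)c(F)c1` has not yet been measured. The change from compound 2 is chloro in place of isopentylsulfanyl on an aromatic carbon. Among the measured compounds shown here, only one measured step bears on this position: a 2.8-fold higher number from compound 1 to compound 2 (0.45 log units; beyond the scatter), where exchanging the group on an aromatic carbon of the shared core moved the number modestly. The present change replaces the whole isopentylsulfanyl chain with chloro, a larger alteration than that step, so a further rise in the number for compound 3 in this assay, about the size of a 2.8-fold higher number from compound 1 to compound 2 (0.45 log units; beyond the scatter) or somewhat more, is expected, though an outcome within the scatter cannot be excluded. Compound 3 is therefore estimated at 5 nM, range 1.5 nM to 16 nM, the expected step being a 3.6-fold higher number from compound 2 to compound 3 (0.55 log units; beyond the scatter).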

Compound 3, inhibition constant: 4 nM
The estimate for compound 3 lay 1.3-fold (0.10 log units) above the measured number, within the range that was stated.
By their numbers in this assay, from the lowest: compound 1; then compound 2; then compound 3.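

In this assay, cutting the isopentylsulfanyl chain back to a single chloro gives a 2.9-fold higher number from compound 2 to compound 3 (0.46 log units; beyond the scatter) and shows that the shared core keeps measurable activity without a long group on this aromatic carbon. Set against the (4-fluorobenzyl)oxy group, the same chloro gives an 8.0-fold higher number from compound 1 to compound 3 (0.90 log units; beyond the scatter) as the widest step so far, and among these three compounds the number rises as the group gets smaller, with none going against that order. No accompanying measurement accounts for these rises.

The three groups differ in both the linking atom and the tail, so the contribution of each cannot be separated. Where an isopentyloxy chain, a (4-fluorobenzyl)sulfanyl group or an amine on this aromatic carbon would fall remains open.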